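From Fluoro to Bromo: Compound 3 Leads to Compound 4

This account rests on a few compounds, and the source may have more. Where it says the series, first, only, none or still open, it means among the compounds named here.

Compound 1 `O=c1ccn(COCCO)c(=O)[nH]1`, compound 2 `O=c1cc([Se]c2ccccc2)n(COCCO)c(=O)[nH]1` and compound 3 `O=c1[nH]c(=O)n(COCCO)c([Se]c2ccccc2)c1F` were tested in a functional assay (Homo sapiens) for cytotoxicity; a lower number here means a stronger inhibitor, a higher number a weaker inhibitor. In this assay compound 1 gives only a limit, > 100000 nM. Compound 2 also gives only a limit, > 100000 nM. Compound 3 likewise reaches only a limit, > 100000 nM. All three values sit at the limit of > 100000 nM in this assay, at which 3 of the 3 values shown sit, so compound 3 stands nowhere more precise than that limit. The step from compound 2 to compound 3 is a step that the two limits leave unreadable from compound 2 to compound 3. Compound 4 `O=c1[nH]c(=O)n(COCCO)c([Se]c2ccccc2)c1Br` differs from compound 3 by bromo in place of fluoro on an aromatic carbon. Among the compounds with values here, no measured step resolves such an exchange, and the neighbouring step cannot be read, so no shift beyond the scatter is expected. Compound 4 is therefore estimated at 100000 nM, within 30000 nM to 300000 nM. The expected step is a number no higher from compound 3 to compound 4 (the limit leaves the size open), most likely again a limit.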

Compound 4, half-maximal inhibitory concentration: > 100000 nM
Compound 4: no number, only a limit (the forecaster's own chance of this, stated with the estimate: 80%); the middle value sits exactly at the limit.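

Compound 4, like compound 2 and compound 3, gives only a limit, so no step among them can be read, and all the values shown sit at one ceiling: the limit of > 100000 nM in this assay, at which 4 of the 4 values shown sit.

Which change to the shared core, if any, would bring a measurable cytotoxic effect in this assay stays open.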